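This account rests on a few compounds, and the source may have more. Where it says the series, first, only, none or still open, it means among the compounds named here.

Compound 1, with the structure `O=C(Nc1cccc(N2CCCC2=O)c1)C1CCCN(C(=O)c2cc(C(F)(F)F)cc(C(F)(F)F)c2)C1`, is one of three compounds examined in an ADME assay on PC-3 cells (Homo sapiens) for cytotoxicity, read by WST assay, tested at 100 uM; a higher number here means more inhibition at the concentration tested (going by the name of the read-out), a lower number less inhibition. In this assay compound 1 gives 0%. Compound 2, with the structure `COC(=O)c1cccc(C(=O)N2CCCC(C(=O)Nc3ccc(Cl)cc3)C2)c1`, gives 0% in this assay, and compound 3, with the structure `CC(C)(C)CC(=O)Nc1cccc(C(=O)N2CCCC(C(=O)Nc3ccc(Cl)cc3)C2)c1`, gives 0%. All three therefore sit together at the floor of the read-out, and compound 1 stands level with compounds 2 and 3, with neither gap reaching beyond the scatter of repeated measurements.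

Compound 4, with the structure `COC(=O)c1cccc(NC(=O)C2CCCN(C(=O)c3cc(C(F)(F)F)cc(C(F)(F)F)c3)C2)c1`, is the next compound to be measured. It differs from compound 1 in one place: methoxycarbonyl in place of 2-oxopyrrolidin-1-yl on an aromatic carbon. Going by the values given here, the only measured step that bears on this change is the one from compound 2 to compound 3, where a different group takes the place of methoxycarbonyl on an aromatic carbon; that step was no change at the digits printed from compound 2 to compound 3 (within the scatter). Swapping the group at that position thus left the read-out unmoved in the one case where it was tried, and both the compound carrying methoxycarbonyl and the compound carrying 2-oxopyrrolidin-1-yl already sit at the floor. On this basis no step beyond the scatter is expected; the estimated step is no change at the digits printed from compound 1 to compound 4 (within the scatter). Compound 4 is therefore expected to give about 0% in this assay, within a range from -10% to 10%.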

Compound 4, a percentage reported as inhibition, at one concentration (the size of the read-out at that concentration, not a potency): 0%
The estimate for compound 4 equals the measured number at the digits printed; measured number inside the range.
By their numbers in this assay, from the lowest: compounds 1, 2, 3 and 4 (each within the scatter of the next).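

In this assay, putting methoxycarbonyl in place of 2-oxopyrrolidin-1-yl on the aromatic carbon, meta to a large group, gives no change at the digits printed from compound 1 to compound 4 (within the scatter). The earlier step involved a different leaving pair on another core, whereas this one shows that on the core of compound 1 the read-out stays at the floor whether the group at this position holds a five-membered non-aromatic ring or no ring at all. No measurement shown here offers an explanation for this lack of change.

A read-out sitting at the floor on both sides of a step cannot show whether the group at this position has any influence on the cells, so this result marks the swap as without visible effect at the tested concentration and nothing finer. Going by these compounds, whether a carboxylic acid, a primary amine or a longer alkyl chain at this position would lift the read-out above the floor remains open, as does whether any change elsewhere on the core of compound 1 would do so.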